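Cytotoxicity notes on the series, compound 3 to compound 4

This account rests on a few compounds, and the source may have more. Where it says the series, first, only, none or still open, it means among the compounds named here.

Compound 1 `CSc1ccc(-n2cc(-c3cn([C@H]4C[C@H](O)[C@@H](CO)O4)c(=O)[nH]c3=O)nn2)cc1`: in an ADME assay on HEL cells (Homo sapiens) for cytotoxicity, read by cell counting, with a stated time of 3 days (a lower number here means that less compound is tolerated, a higher number that more compound is tolerated), compound 1 sits at a limit of the assay, > 230000 nM.
Compound 2 `O=c1[nH]c(=O)n([C@H]2C[C@H](O)[C@@H](CO)O2)cc1-c1cn(-c2ccc(Oc3ccccc3)cc2)nn1`: in this assay compound 2 gives 130000 nM.
Compound 3 `O=c1[nH]c(=O)n([C@H]2C[C@H](O)[C@@H](CO)O2)cc1-c1cnnn1-c1c(F)cccc1F`: in this assay compound 3 sits at a limit of the assay, > 100000 nM.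

Compound 3 therefore stands at a limit rather than at a number; of the three values shown, only compound 2 carries a proper number, and two are limits, one of them being the limit of > 100000 nM in this assay, at which 1 of the 3 values shown sits, and the other (the limit of > 230000 nM in this assay, at which 1 of the 3 values shown sits).

Compound 4 `O=c1[nH]c(=O)n([C@H]2C[C@H](O)[C@@H](CO)O2)cc1-c1cnnn1-c1ccc(Br)cc1` differs from compound 3 in one place: 4-bromophenyl in place of 2,6-difluorophenyl on an aromatic nitrogen.

Going by the values given here, only one measured step exists, an at least 1.7-fold lower number from compound 1 to compound 2 (0.24 log units; that floor lies within the scatter), and it concerns a change on an aromatic carbon, not on the aromatic nitrogen touched here; it is itself not resolved from the scatter. Among the compounds with values here, no measured step bears directly on the exchange of 2,6-difluorophenyl for 4-bromophenyl on the aromatic nitrogen. Within the data shown here, with compound 3 at a limit and no comparable step in hand, no step beyond the scatter is expected in this assay in either direction, and a further limit is the likelier outcome.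

Compound 4 is estimated at 100000 nM, with a range from 50000 nM to 230000 nM.

The step this estimate implies, a number no higher from compound 3 to compound 4 (the limit leaves the size open), is expected to lie within the scatter.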

Compound 4, minimum cytotoxic concentration: > 100000 nM
Compound 4 gave a limit, no number; the forecaster's own chance of this, stated with the estimate: 60%; the middle value sits exactly at the limit.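

In this assay compound 3 and compound 4 both stand at a limit, and no step can be read between them: the limit of > 100000 nM in this assay, at which 2 of the 4 values shown sit.

The compounds shown leave open whether 4-bromophenyl in place of 2,6-difluorophenyl on an aromatic nitrogen shifts the minimum cytotoxic concentration at all, and in which direction, in this assay.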